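Swapping the para substituent: fluoro to tert-butyl

The compounds below may be only part of what the source reports. "The series", "measured", "known", "first", "only" and "open" are said of these compounds alone.

Measured so far in an assay on cells for activation of probable G-protein coupled receptor 34 (Mus musculus), with a stated time of 1 h; on this read-out lower numbers stand for smaller maximal responses and higher numbers for larger maximal responses:
compound 1 `N[C@@H](COP(=O)(O)OCCCOC(=O)CCc1ccccc1OCc1cccc(Oc2ccc(Cl)cc2)c1)C(=O)O` gives 0.76;
compound 2 `N[C@@H](COP(=O)(O)OCCCOC(=O)CCc1ccccc1OCc1cccc(Oc2ccc(F)cc2)c1)C(=O)O` gives 0.66.

Compound 2 gives the lower of the two numbers, with compound 1 sitting within the scatter. Compound 3 `CC(C)(C)c1ccc(Oc2cccc(COc3ccccc3CCC(=O)OCCCOP(=O)(O)OC[C@H](N)C(=O)O)c2)cc1` differs from compound 2 by tert-butyl in place of fluoro on an aromatic carbon. For the measured compounds named here, the only step that touches this position is a number 0.10 lower from compound 1 to compound 2 (within the scatter), which stayed within the scatter, so a step of similar modest size, leaning slightly upward, is expected here: a number 0.060 higher from compound 2 to compound 3 (within the scatter). For compound 3 the expected value in this assay is 0.72, ranging from 0.52 to 0.92.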

Compound 3, intrinsic activity: the largest response reached, as a fraction of the reference agonist's: 0.079
Estimate against measurement, compound 3: 0.64 above; measured number below the stated range.
By their numbers in this assay, from the lowest: compound 3; then compounds 2 and 1 (each within the scatter of the next).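

In this assay, this position turns out to be far less tolerant than the swap of chloro for fluoro suggested: tert-butyl gives a number 0.58 lower from compound 2 to compound 3 (beyond the scatter) and a number 0.68 lower from compound 1 to compound 3 (beyond the scatter). Chloro and fluoro, within the scatter of each other, both keep a sizeable maximal response, whereas tert-butyl leaves little of it. Nothing available here accounts for this drop.

The compounds shown leave open how a methyl, isopropyl or methoxy group on this aromatic carbon would fare. They also leave open whether the response falls gradually or abruptly across such groups.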